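A few compounds are considered here, and "the series" means these few. Any claim that something is new, unique, unknown or untested is made for them only; others in the source may bear on it.

Of the compounds shown here, two with a shared core have been measured so far in a functional assay on HCT-116 cells (Homo sapiens) for cytotoxicity (on this read-out higher numbers stand for weaker inhibition and lower numbers for stronger inhibition), as the test. Compound 1 `COc1cc(N2CCN(C(=O)N3CCN(C)CC3)CC2)ccc1Nc1nc(NC2CCCCC2)c2nc[nH]c2n1` gives 17 nM there and compound 2 `COc1cc(N2CCC(CC(=O)N3CCOCC3)CC2)ccc1Nc1nc(NC2CCCCC2)c2nc[nH]c2n1` gives 36 nM there, so compound 2 holds the higher of the two numbers, with a gap to compound 1 that lies just beyond the usual scatter. Compound 3 `COc1cc(N2CCC(CC(=O)N3CCCC3)CC2)ccc1Nc1nc(NC2CCCCC2)c2nc[nH]c2n1` differs from compound 2 by a single exchange. The exchange pyrrolidin-1-yl in place of morpholin-4-yl on a carbonyl carbon puts pyrrolidin-1-yl in place of morpholin-4-yl on a carbonyl carbon. Among the measured compounds shown here, no measured pair differs in only one place, so the data hold no direct precedent for it. Compound 1 at 17 nM and compound 2 at 36 nM stand only just beyond the scatter of each other although they differ in more than one place. On that ground a step in this assay no larger than the scatter is expected, with a slight lean towards a lower number. The estimated step is a 1.2-fold lower number from compound 2 to compound 3 (0.08 log units; within the scatter) and it stays within the scatter. For compound 3 the expected value is 30 nM with an estimated range from 12 nM to 75 nM in this measurement.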

Compound 3, half-maximal inhibitory concentration: 15 nM
Beside the measured number, compound 3's estimate is 2.0-fold (0.30 log units) above it; the measured number falls inside the stated range.
By their numbers in this assay, from the lowest: compounds 3 and 1 (each within the scatter of the next); then compound 2.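

In this assay, among the compounds shown here, the exchange of morpholin-4-yl for pyrrolidin-1-yl on a carbonyl carbon gives a 2.4-fold lower number from compound 2 to compound 3 (0.38 log units; beyond the scatter), which is the only single-place comparison available and shows that the read-out responds to the group at this position. The change is modest, but it shows that the morpholin-4-yl ring can be replaced by a smaller ring with one fewer hetero atom, and by a group with no hydrogen-bond acceptor as counted here, without a loss on this read-out. No measurement is available that explains the step.

This single pair changes ring size and removes the ring oxygen at once, so it cannot show whether either difference alone accounts for the step, and piperidin-1-yl, which has a six-membered ring without the oxygen, would separate the two. It also leaves open whether an open-chain amine such as dimethylamino on the same carbonyl carbon, or a longer chain between that carbonyl and the saturated ring, would keep the number of compound 3 at 15 nM.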